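A few compounds are considered here, and "the series" means these few. Any claim that something is new, unique, unknown or untested is made for them only; others in the source may bear on it.

Compound 1 `O=C(CSc1nc(Nc2ccccc2)c2ccccc2n1)Nc1cccc(F)c1` gives only a limit in a functional assay on MDA-MB-231 cells (Homo sapiens) for inhibition, read by MTT assay, with a stated time of 72 h (on this read-out lower numbers stand for stronger inhibition and higher numbers for weaker inhibition), > 50000 nM. Compound 2 `CCc1ccc(NC(=O)CSc2nc(Nc3ccccc3)c3ccccc3n2)cc1` gives 33900 nM in this assay. Compound 3 `C=CC(=O)Nc1cccc(NC(=O)CSc2nc(Nc3ccccc3F)c3ccccc3n2)c1` gives 18700 nM in this assay.

Among the measured compounds shown here, compound 3 holds the lowest of the two numbers, with compound 2 within the scatter of it; the gap an at least 1.4-fold lower number from compound 1 to compound 2 (0.16 log units; that floor lies within the scatter) is the only measured step, and its floor is within the scatter (the limit of > 50000 nM in this assay, at which 1 of the 3 values shown sits). Compound 4 `C=CC(=O)Nc1cccc(NC(=O)CSc2nc(Nc3cccc(C)c3)c3ccccc3n2)c1` differs from compound 3 by 3-methylphenyl in place of 2-fluorophenyl on a nitrogen on an aromatic ring. For the measured compounds named here, no measured step touches that nitrogen, so the step from compound 3 to compound 4 in this assay is expected to be no larger than the scatter, direction open: a 1.0-fold lower number from compound 3 to compound 4 (0.02 log units; within the scatter). Compound 4 is estimated at 18000 nM, between 6000 nM and 50000 nM.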

Compound 4, half-maximal inhibitory concentration: 16800 nM
Compound 4: middle estimate off by 1.1-fold (0.03 log units), on the high side; low and high end bracket the measured number.
By their numbers in this assay, from the lowest: compounds 4, 3 and 2 (each within the scatter of the next). At a limit, above all of these: compound 1.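

Among the compounds shown here, the first measured change at this nitrogen on an aromatic ring, 3-methylphenyl in place of 2-fluorophenyl, gives a 1.1-fold lower number from compound 3 to compound 4 (0.05 log units; within the scatter). In this assay, this place therefore accepts either substituted phenyl without a readable difference. The step swaps the substituent and its ring position together, so neither can be read alone.

As far as these compounds go, whether an amine, a carboxylic acid or a longer chain at this nitrogen would move the number beyond the scatter stays open. Compound 1 gives only a limit, which leaves its actual value open: the limit of > 50000 nM in this assay, at which 1 of the 4 values shown sits.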